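The compounds below may be only part of what the source reports. "The series", "measured", "known", "first", "only" and "open" are said of these compounds alone.

Compound 1 `C[C@H]1[C@H](NCc2cc(C3CC3)cs2)C[C@H]2C[C@@H]1C2(C)C` gives 25000 nM in an ADME assay on MDCK cells (Canis lupus familiaris) for cytotoxicity, read by microscopy, with a stated time of 48 h; on this read-out lower numbers stand for higher toxicity in this test and higher numbers for lower toxicity in this test. Compound 2 `C[C@H]1[C@H](NCc2cncs2)C[C@H]2C[C@@H]1C2(C)C` gives only a limit in this assay, > 100000 nM. Compound 3 `Cc1ccc(CN[C@@H]2C[C@H]3C[C@@H]([C@H]2C)C3(C)C)s1` gives 780 nM.

Among the numbers shown, compound 1 stands highest, and its nearest neighbour is compound 3. Compound 4 `C[C@H]1[C@H](NCc2cc(C3CCCC3)cs2)C[C@H]2C[C@@H]1C2(C)C` differs from compound 1 by cyclopentyl in place of cyclopropyl on an aromatic carbon. Going by the values given here, the one step measured, an at least 120-fold lower number from compound 2 to compound 3 (2.10 log units; beyond the scatter), changes the aromatic ring itself and sits against (the limit of > 100000 nM in this assay, at which 1 of the 3 values shown sits), so it does not bear directly on a change of the group on the thiophene. Compounds 1 and 3 show that a cyclopropyl gives a higher number than a methyl at this position. For compound 4 the step of a 1.2-fold higher number from compound 1 to compound 4 (0.08 log units; within the scatter) is therefore expected to stay within the scatter, and compound 4 is estimated at 30000 nM, with a range from 8000 nM to 100000 nM.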

Compound 4, minimum cytotoxic concentration: 1560 nM
Compound 4: the middle estimate sits 19-fold (1.28 log units) above what was measured, and the stated range ends above it.
By their numbers in this assay, from the lowest: compounds 3 and 4 (each within the scatter of the next); then compound 1. At a limit, above all of these: compound 2.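

In this assay, the group on this aromatic carbon proves to matter: cyclopentyl in place of cyclopropyl alone gives a 16-fold lower number from compound 1 to compound 4 (1.20 log units; beyond the scatter). A swap between two carbon-only rings, neither carrying a hydrogen-bond donor or acceptor, is thus enough to move the read-out by a large step. Nothing measured here gives a reason for this step.

From the compounds shown here alone, what a cyclobutyl, a phenyl or an amine would give on this carbon remains open. So does whether the read-out follows ring size at all.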